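Tert-butyl replacing fluorophenyl on the pyrazole nitrogen

A few compounds are considered here, and "the series" means these few. Any claim that something is new, unique, unknown or untested is made for them only; others in the source may bear on it.

Compound 1 `Cc1ccc(-n2nc(C(C)(C)C)cc2NC(=O)Nc2cc(F)cc(F)c2)cc1`: 0.6 degrees C
Compound 2 `CC(C)(C)c1cc(NC(=O)Nc2cc(F)cc(F)c2)n(-c2ccc(F)cc2)n1`: 1.7 degrees C

Compound 2 stands highest of the two numbers in an assay on isolated protein for inhibition of serine/threonine-protein kinase 10 (Homo sapiens), read by thermal shift assay, tested at 10 uM (a lower number here means that the compound stabilises the target less, a higher number that the compound stabilises the target more against heat), and its nearest neighbour is compound 1, where the step of a number 1.1 degrees C higher from compound 1 to compound 2 (beyond the scatter) is the only one measured. Compound 3 `CC(C)(C)c1cc(NC(=O)Nc2cc(F)cc(F)c2)n(C(C)(C)C)n1` differs from compound 2 by tert-butyl in place of 4-fluorophenyl on an aromatic nitrogen. Within the data shown here, no measured step concerns this ring nitrogen; the step from compound 1 to compound 2 only changed a substituent on the group that now leaves, so it bears on the change indirectly. The author therefore expects a small step, a number 0.70 degrees C lower from compound 2 to compound 3 (within the scatter), without confidence in its direction, and estimates that compound 3 gives 1 degrees C, within -0.5 degrees C to 2.5 degrees C in this assay.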

Compound 3, shift of the target's melting temperature: -0.2 degrees C
Beside the measured number, compound 3's estimate is 1.2 degrees C above it, and the stated range covers the measured number.
By their numbers in this assay, from the lowest: compounds 3 and 1 (each within the scatter of the next); then compound 2.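

At this aromatic nitrogen, the outcome of entering tert-butyl in this assay depends on which group leaves. Replacing 4-fluorophenyl gives a number 1.9 degrees C lower from compound 2 to compound 3 (beyond the scatter), whereas replacing 4-methylphenyl gives a number 0.80 degrees C lower from compound 1 to compound 3 (within the scatter), so only the first replacement separates the compounds. Nothing given here explains this difference.

On these data alone, it remains open whether an ethyl group or a chain ending in an amine on this nitrogen would retain the stabilisation seen with compound 2. As far as these compounds go, whether any such group would surpass 4-fluorophenyl also remains open.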